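The source may report more compounds than this note shows. Statements on the series, on what has been measured and on what is new or still open speak of the compounds shown alone.

Measured so far:
compound 1 `N#Cc1c(-c2ccc(Cl)cc2)nc(SCc2ccccc2)nc1N1CCC(C(=O)c2ccccc2)CC1`: > 10000 nM
compound 2 `COc1ccc(-c2nc(SCc3ccccc3)nc(NCc3cccs3)c2C#N)cc1`: > 10000 nM

Both were tested in an ADME assay on Jurkat cells (Homo sapiens) for cytotoxicity, read by WST assay, with a stated time of 48 h; on this read-out lower numbers stand for higher toxicity in this test and higher numbers for lower toxicity in this test. For compound 1 the value > 10000 nM is a limit of the assay, not a number. For compound 2 the value > 10000 nM is also a limit. Compound 2 therefore stands at the limit of > 10000 nM in this assay, at which 2 of the 2 values shown sit, together with the other value shown.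

Compound 3 `COc1ccc(-c2nc(SCc3ccccc3)nc(NCc3ccccc3)c2C#N)cc1` differs from compound 2 in one place: phenyl in place of thiophen-2-yl on a saturated chain carbon bound to a nitrogen on an aromatic ring. Among the compounds with values here, no step between two measured compounds is available here. In this assay the expected step is a step that the limit leaves unreadable from compound 2 to compound 3, none beyond the usual scatter. Compound 3 is estimated at 15000 nM, within 7000 nM to 40000 nM.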

Compound 3, half-maximal cytotoxic concentration: > 10000 nM
Compound 3: a limit, no number; the forecaster's own chance of this, stated with the estimate: 85%; the middle value lies beyond the limit too.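

Compound 2 and compound 3 both give only a limit in this assay, not a number, so no step between them can be read: the limit of > 10000 nM in this assay, at which 3 of the 3 values shown sit.

The compounds shown leave open whether phenyl in place of thiophen-2-yl changes the toxicity at all, and at what concentration any of them would become toxic.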